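Chain shortening at the aromatic nitrogen in a cyclic-amine series

A few compounds are considered here, and "the series" means these few. Any claim that something is new, unique, unknown or untested is made for them only; others in the source may bear on it.

Measured compounds in an assay on CHO cells for displacement of a labelled ligand from adenosine receptor A3 (Homo sapiens), read by scintillation counting, with a stated time of 3 h; on this read-out higher numbers stand for weaker inhibition and lower numbers for stronger inhibition:
- compound 1 `CCn1c(-c2ccccc2)nc2c(NC3CCC3)ncnc21`: 84 nM
- compound 2 `CCCn1c(-c2ccccc2)nc2c(NC3CCC3)ncnc21`: 264 nM
- compound 3 `CCn1c(-c2ccccc2)nc2c(NC3CCOC3)ncnc21`: 1660 nM

Compound 1 and compound 2 share a core and differ only by hydrogen in place of methyl on a saturated chain carbon, two bonds along the chain from an aromatic nitrogen. That shortening gives a 3.1-fold lower number from compound 2 to compound 1 (0.50 log units; beyond the scatter), a modest step in favour of the shorter chain. Compound 3 carries the ethyl chain of compound 1 but differs from it by hydrogen in place of methyl on a saturated chain carbon bound to an aromatic nitrogen being absent; instead it differs by the cyclic amine, and the step is a 20-fold higher number from compound 1 to compound 3 (1.30 log units; beyond the scatter), a large loss. Compound 3 stands highest of the three numbers. The difference between the cores of compound 3 and compound 2 is not broken down here.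

Compound 4 `Cn1c(-c2ccccc2)nc2c(NC3CCOC3)ncnc21` is not yet measured. It differs from compound 3 by hydrogen in place of methyl on a saturated chain carbon bound to an aromatic nitrogen. Among the compounds with values here, this is the same kind of change as the one from compound 2 to compound 1, but not the same: there the carbon that loses the methyl sits two bonds along the chain from an aromatic nitrogen, here it is bound directly to the aromatic nitrogen. Within the data shown here, only one such step is known, so the expectation rests on the single modest gain seen in a 3.1-fold lower number from compound 2 to compound 1 (0.50 log units; beyond the scatter). The step from compound 3 to compound 4 is estimated at a 1.8-fold lower number from compound 3 to compound 4 (0.27 log units; within the scatter), with wide bounds, since a cut one bond closer to the ring may not behave like the measured one. Compound 4 is therefore expected to give about 900 nM in this assay, most likely between 300 nM and 2700 nM.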

Compound 4, inhibition constant: 6260 nM
For compound 4 the middle estimate is 7.0-fold (0.84 log units) below the measured one; measured number above the stated range.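

In this assay, hydrogen in place of methyl on a saturated chain carbon bound to an aromatic nitrogen gives a 3.8-fold higher number from compound 3 to compound 4 (0.58 log units; beyond the scatter), a modest loss, and this differs clearly from the earlier step: the same change on two cores in this assay, a 3.1-fold lower number (0.50 log units; beyond the scatter) from compound 2 to compound 1 and a 3.8-fold higher number (0.58 log units; beyond the scatter) from compound 3 to compound 4, 12-fold (1.07 log units) apart, beyond the scatter of two such steps

Shortening the chain at the aromatic nitrogen therefore does not carry over as a general gain in this series, and the result seen with the cyclobutyl group cannot be transferred to the oxolan-3-yl compounds. It does not show what separates the two steps, since they differ both in the group on the other nitrogen, cyclobutyl or oxolan-3-yl, and in the place of the cut, two bonds along the chain from an aromatic nitrogen or on the carbon bound to it, and a single step of each kind cannot separate these two differences.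

The compounds shown leave open how a methyl on the aromatic nitrogen behaves with the cyclobutyl group and how a propyl chain behaves with the oxolan-3-yl group, either of which would place both cuts on one core. Also open, from the compounds shown here alone, is whether a longer chain such as butyl, or a branched isopropyl group, would follow either trend.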